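This account rests on a few compounds, and the source may have more. Where it says the series, first, only, none or still open, it means among the compounds named here.

Measured compounds:
compound 1 `C#Cc1cccc(C#Cc2ccc(CCC(=O)O)cc2)c1` gives 155 nM in an in vitro functional assay on 1321-N1 cells for agonist activity at Free fatty acid receptor 1 (Homo sapiens), read by fluorescence; a higher number here means that more compound is needed for the effect, a lower number that less compound is needed;
compound 2 `Cc1ccccc1C#Cc1ccc(OCC(=O)O)cc1` gives 3720 nM in this assay;
compound 3 `O=C(O)COc1ccc(C#Cc2ccccc2)cc1` gives 1260 nM in this assay.

Of these three, compound 1 gives the lowest number, so it needs the least compound to reach the half-maximal effect; compound 3 and compound 2 both need more. Going by the values given here, the only step between measured compounds that differ in one place is a 3.0-fold lower number from compound 2 to compound 3 (0.47 log units; beyond the scatter), where the change is hydrogen in place of methyl on an aromatic carbon.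

Compound 4 `O=C(O)CCc1ccc(C#Cc2cccc([N+](=O)[O-])c2)cc1` is the unmeasured compound. It differs from compound 1 in one place: nitro in place of ethynyl on an aromatic carbon. The nitro sits on an aromatic carbon of a six-membered aromatic ring of carbon only, meta to a large group. Among the compounds with values here, the one measured step concerns a different group on the other ring and with another acid chain, so it does not bear directly on this change; no measured step compares a nitro with an ethynyl. With nothing in the data pointing clearly either way, a step of moderate size at most is expected, more likely toward a higher number than a lower one, and a result within the scatter of compound 1 would not be surprising. For compound 4 the number expected is 300 nM, with a range from 80 nM to 1200 nM. The expected step from compound 1 is a 1.9-fold higher number from compound 1 to compound 4 (0.29 log units; within the scatter).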

Compound 4, half-maximal effective concentration: 58.9 nM
The estimate for compound 4 lay 5.1-fold (0.71 log units) above the measured number, outside the stated range (below it).
By their numbers in this assay, from the lowest: compound 4; then compound 1; then compound 3; then compound 2.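

In this assay, going by these compounds alone, nitro in place of ethynyl on this aromatic carbon, meta to a large group, gives a 2.6-fold lower number from compound 1 to compound 4 (0.42 log units; beyond the scatter) and so moves the number in a direction the earlier compounds could not reveal. The ethynyl of compound 1 is therefore not required at this position: a group with no triple bond, carrying hydrogen-bond acceptors that ethynyl lacks, is not merely accepted but needs less compound for the effect. Nothing measured here accounts for this drop.

On these data alone, whether nitro itself matters remains open, since a nitrile, a trifluoromethyl or a methoxy group at the same carbon would show how particular this result is. As far as these compounds go, it is also open whether a nitro group would lower the number on compound 3, which carries a different acid chain.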